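The compounds below may be only part of what the source reports. "The series", "measured", "known", "first", "only" and "open" are said of these compounds alone.

Within the data shown here, compound 3 `CCCCCCCCCCCCCCCCCCNC(=O)[C@@H]1CSC(c2ccc(N(C)C)cc2)N1` stands second highest of the three numbers measured so far: in a functional assay on TSU-Pr1 cells (Homo sapiens) for antiproliferative activity, read by sulforhodamine B assay (a higher number here means a weaker inhibitor, a lower number a stronger inhibitor), compound 3 gives 3000 nM. Compound 2 `CCCCCCCCCCCCCCCCCCNC(=O)[C@@H]1CSC(c2cc(OC)c(OC)c(OC)c2)N1` is nearest, as in this assay compound 2 gives 2400 nM and a 1.3-fold higher number from compound 2 to compound 3 (0.10 log units; within the scatter). Compound 1 `CCCCCCCCCCCCCCCCCCNC(=O)[C@@H]1CSC(c2ccc(OC)cc2)N1` is furthest, since in this assay compound 1 gives 19600 nM, with a 6.5-fold lower number from compound 1 to compound 3 (0.82 log units; beyond the scatter) and an 8.2-fold lower number from compound 1 to compound 2 (0.91 log units; beyond the scatter). Compound 4 `CCCCCCCCCCCCCCCCCCNC(=O)[C@@H]1CSC(c2ccc(O)cc2)N1` differs from compound 3 in one place: hydroxy in place of dimethylamino on an aromatic carbon. Among the measured compounds shown here, no measured step tests a hydroxy at this position. For the measured compounds named here, the only step at this aromatic carbon is a 6.5-fold lower number from compound 1 to compound 3 (0.82 log units; beyond the scatter), a modest one, and the change to compound 4 takes out the dimethylamino that entered in that step. A modest move back toward the number of compound 1 is therefore the working expectation, with the caveat that nothing measured shows whether hydroxy tracks methoxy. The step expected is a 3.0-fold higher number from compound 3 to compound 4 (0.48 log units; beyond the scatter). Compound 4 is estimated at 9000 nM in this assay, with a range of 2500 nM to 30000 nM.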

Compound 4, half-maximal inhibitory concentration: 3000 nM
Beside the measured number, compound 4's estimate is 3.0-fold (0.48 log units) above it; the measured number falls inside the stated range.
By their numbers in this assay, from the lowest: compounds 2, 3 and 4 (each within the scatter of the next); then compound 1.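

In this assay, the change at this aromatic carbon, para to a large group, gives no change at the digits printed from compound 3 to compound 4 (within the scatter), so hydroxy and dimethylamino cannot be told apart here, even though they differ in heavy atoms and hydrogen-bond donors. Taking only the methyl off the oxygen gives a 6.5-fold lower number from compound 1 to compound 4 (0.82 log units; beyond the scatter), which makes methoxy the one group among these three at this carbon that goes against the otherwise matching numbers. The 4-hydroxyphenyl group also stands level with the 3,4,5-trimethoxyphenyl group, with a 1.3-fold higher number from compound 2 to compound 4 (0.10 log units; within the scatter), so one hydroxy serves as well here as three methoxy groups. Still open, from the compounds shown here alone, is whether an ethoxy group, a primary amine or a carboxylic acid at this carbon would track compound 1 or compound 4. No evidence on hand explains why methoxy parts from hydroxy and dimethylamino.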